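Phenyl exchange on the carbonyl carbon: compound 3 to compound 4

The compounds below may be only part of what the source reports. "The series", "measured", "known", "first", "only" and "open" are said of these compounds alone.

Measured so far in a functional assay on MOLT-4 cells (Homo sapiens) for antiproliferative activity, with a stated time of 48 h (a higher number here means a weaker inhibitor, a lower number a stronger inhibitor), with the shared core unchanged:
compound 1 `C=C(Br)C(=O)Nc1ccc(/C=C/C(=O)c2ccc(Cl)c(Cl)c2)cc1` gives 1800 nM
compound 2 `C=C(Br)C(=O)Nc1ccc(/C=C/C(=O)c2ccc(Br)cc2)cc1` gives 680 nM
compound 3 `C=C(Br)C(=O)Nc1ccc(/C=C/C(=O)c2ccc(C)cc2)cc1` gives 1700 nM

Compound 3 is not separated from compound 1, with a 1.1-fold lower number from compound 1 to compound 3 (0.02 log units; within the scatter) on record. Only the 4-bromophenyl compound stands apart, with a 2.5-fold higher number from compound 2 to compound 3 (0.40 log units; beyond the scatter) on record.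

Compound 4 `C=C(Br)C(=O)Nc1ccc(/C=C/C(=O)c2cccc(OC)c2)cc1` comes next, with 3-methoxyphenyl in place of 4-methylphenyl on a carbonyl carbon as the counted difference: 3-methoxyphenyl in place of 4-methylphenyl on a carbonyl carbon. All three measured steps are exchanges on this same carbonyl carbon. The widest of them, a 2.6-fold lower number from compound 1 to compound 2 (0.42 log units; beyond the scatter) as recorded, is modest. Among the measured compounds shown here, none of the measured compounds carries a 3-methoxyphenyl, so this exchange has no direct precedent and its direction stays open.

Compound 1 at 1800 nM and compound 2 at 680 nM mark the span reached so far, so a modest step at most is expected in this assay, and more likely none beyond the scatter. The estimated step is a 1.3-fold lower number from compound 3 to compound 4 (0.12 log units; within the scatter) as a working figure. Compound 4 is estimated at 1300 nM with an expected range from 500 nM to 3200 nM for the coming measurement.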

Compound 4, half-maximal inhibitory concentration: 850 nM
For compound 4 the middle estimate is 1.5-fold (0.18 log units) above the measured one; low and high end bracket the measured number.
By their numbers in this assay, from the lowest: compounds 2, 4, 3 and 1 (each within the scatter of the next, the first and the last beyond it).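

In this assay the exchange of 4-methylphenyl for 3-methoxyphenyl on the carbonyl carbon, which brings 1 hydrogen-bond acceptor where 4-methylphenyl has 0, gives a 2.0-fold lower number from compound 3 to compound 4 (0.30 log units; within the scatter) and so cannot be told apart from no change. Compound 4 is likewise not separated from the 4-bromophenyl compound, with a 1.3-fold higher number from compound 2 to compound 4 (0.10 log units; within the scatter) on record, although compound 2 and compound 3 remain separated from each other, so the four values form a continuous run with no clear break. Among the compounds shown here, with a 2.1-fold lower number from compound 1 to compound 4 (0.33 log units; beyond the scatter) as the only step from compound 4 beyond the scatter, 3-methoxyphenyl becomes the second group at this position, after 4-bromophenyl, to be separated from 3,4-dichlorophenyl, though only modestly. No measurement at hand gives a reason for any of these steps.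

The compounds shown leave open whether the oxygen or its place on the ring matters, as 4-methoxyphenyl would be needed to compare with 3-methoxyphenyl, and whether an amine or a carboxylic acid on this phenyl would move the value beyond the narrow span seen so far. The shared core stays unchanged throughout, so these exchanges say nothing about changes elsewhere in the molecule.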